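This account rests on a few compounds, and the source may have more. Where it says the series, first, only, none or still open, it means among the compounds named here.

Working notes on the series. In an assay on lysate for inhibition of 6-phosphofructo-2-kinase/fructose-2,6-bisphosphatase 3 (Homo sapiens), with stated times of 0.5 min and 45 min (on this read-out higher numbers stand for weaker inhibition and lower numbers for stronger inhibition), compound 1 `CN1CCCC(NS(=O)(=O)c2ccccc2Nc2cc(-c3ccc4ccn(C)c4c3)c3nccnc3c2)C1` gives 9780 nM. Compound 2 `Cn1cc(CNS(=O)(=O)c2ccccc2Nc2cc(-c3ccc4ccn(C)c4c3)c3nccnc3c2)cn1` gives only a limit in this assay, > 100000 nM (the limit of > 100000 nM in this assay, at which 1 of the 3 values shown sits). Among the compounds with values here, the single measured step, an at least 10-fold higher number from compound 1 to compound 2 (1.00 log units; beyond the scatter), sits on a sulfonamide nitrogen. Compound 3 `Cn1ccc2ccc(-c3cc(Nc4cnccc4C(=O)NC4CCNC(=O)C4)cc4nccnc34)cc21` gives 56500 nM, the highest of the two numbers and the weaker of the two inhibitors with a number. Compound 4 `CC(=O)N1CCC(NC(=O)c2ccncc2Nc2cc(-c3ccc4ccn(C)c4c3)c3nccnc3c2)C1` differs from compound 3 by 1-acetylpyrrolidin-3-yl in place of 2-oxopiperidin-4-yl on an amide-type nitrogen. Within the data shown here, no measured step touches an amide-type nitrogen; the step on the sulfonamide nitrogen is the only guide and was at least modest, so little more than scatter is expected here. Compound 4 is expected to sit near compound 3, the expected step being a 1.2-fold higher number from compound 3 to compound 4 (0.06 log units; within the scatter), toward weaker inhibition if anything. The estimate for compound 4 is 65000 nM, with a range from 20000 nM to 200000 nM and a fair chance that this assay reports only a limit.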

Compound 4, half-maximal inhibitory concentration: > 100000 nM
Compound 4: a limit, no number; the forecaster's own chance of this, stated with the estimate: 35%; middle value at least 1.5-fold (0.18 log units) from the limit.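

Within the data shown here, on the amide-type nitrogen, 1-acetylpyrrolidin-3-yl in place of 2-oxopiperidin-4-yl gives an at least 1.7-fold higher number from compound 3 to compound 4 (0.24 log units; that floor lies within the scatter) and offers the first reading at this position, though only as a floor. Compound 4 is a limit and not a number, and the true size of the step stays unread: the limit of > 100000 nM in this assay, at which 2 of the 4 values shown sit.

As far as these compounds go, whether a free amine on the pyrrolidine ring in place of the acetyl group, or a carboxylic acid on this chain, would give a lower number stays open.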